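From 4-methylbenzyl to phenyl on the amide nitrogen

The source may hold more compounds than are shown below. What is called first, only, known or untested is meant among the compounds shown, and "the series" means these compounds.

In a functional assay on K562 cells (Homo sapiens) for cytotoxicity, read by MTT assay, with a stated time of 48 h (on this read-out lower numbers stand for stronger inhibition and higher numbers for weaker inhibition), compound 1 `CCOC(=O)C1(C(=O)Nc2ccccc2)CC1c1cc(OC)c(OC)c(OC)c1` gives > 100000 nM; > 100000 nM (2 entries) as a limit of the assay. Compound 2 `CCOC(=O)[C@@]1(C(=O)NCc2ccc(C)cc2)C[C@H]1c1cc(OC)c(OC)c(OC)c1` likewise gives only a limit, > 100000 nM in both cases without a single number. Compound 3 `CCOC(=O)[C@@]1(C(=O)Nc2ccccc2)C[C@H]1c1cc(OC)c(OC)c(OC)c1` has phenyl in place of 4-methylbenzyl on an amide-type nitrogen and is otherwise unchanged. Among the measured compounds shown here, no measured step is available to size this change. With compound 2 at > 100000 nM as the limit for comparison, no step beyond the scatter is expected in this assay and the estimated step of a number no higher from compound 2 to compound 3 (the limit leaves the size open) has no clear direction. For compound 3 the estimated value is 100000 nM with an expected range from 30000 nM to 200000 nM in this read-out.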

Compound 3, half-maximal inhibitory concentration: > 100000 nM
Compound 3 ended at the assay's limit; the forecaster's own chance of this, stated with the estimate: 75%; the middle value sits exactly at the limit.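

In this assay compound 3 gives > 100000 nM, a limit and not a number. Compound 2 gives > 100000 nM, also a limit. No step can be read between compound 2 and compound 3. Left open is how phenyl and 4-methylbenzyl on the amide-type nitrogen compare in this assay.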